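This account rests on a few compounds, and the source may have more. Where it says the series, first, only, none or still open, it means among the compounds named here.

Compound 1, drawn as `COc1ccc([C@H]2O[C@H](c3cc(OC)c(OC)c(OC)c3)[C@@H](C)[C@@H]2C)cc1OC`, was examined in a functional assay on SK-MEL-2 cells (Homo sapiens) for cytotoxicity, read by sulforhodamine B assay; a lower number here means a stronger inhibitor, a higher number a weaker inhibitor. Compound 1 gives there > 10000 nM, which is a limit of the assay rather than a measured number, so its standing can only be described as at that limit. Two companions were studied alongside it. Compound 2, with the structure `C/C=C/c1cc(OC)c(O[C@H](C)[C@H](O)c2ccc(OC)c(OC)c2)c(OC)c1`, returns in this assay > 10000 nM, again a limit. Compound 3, built as `COc1cc([C@@H]2O[C@@H](c3cc(OC)c(O)c(OC)c3)[C@H](CO[C@@H]3O[C@H](CO)[C@@H](O)[C@H](O)[C@H]3O)[C@H]2CO)cc(OC)c1O`, likewise gives > 10000 nM, a limit as well. Taken together, the picture is summarised by the limit of > 10000 nM in this assay, at which 3 of the 3 values shown sit; no numbered value exists among the three, and no step between any pair of them can be sized.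

Compound 4, drawn as `COc1ccc([C@H]2O[C@H](c3cc(OC)c(OC)c(OC)c3)[C@@H](C)[C@H]2C)cc1OC`, has not yet been measured in this assay. Its relation to compound 1 is narrow: the two compounds have the same atoms and bonds and differ only in configuration as drawn: 1 of 4 stereo elements differ; a stereocentre at a saturated ring carbon is drawn S in compound 1 and R in compound 4. Among the compounds with values here, with every measured compound sitting at the same limit, there is no measured step on which to build a direction. The expectation is therefore that the step from compound 1 to compound 4 amounts to nothing beyond the scatter, expressed as a step that the limit leaves unreadable from compound 1 to compound 4. For compound 4 the estimated value in this assay is 15000 nM, with an expected range from 5000 nM to 50000 nM, and most likely the assay will again report only a limit.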

Compound 4, half-maximal inhibitory concentration: 4530 nM
The estimate for compound 4 lay 3.3-fold (0.52 log units) above the measured number; measured number below the stated range.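

The set now holds its first numbered value, and it comes from a change of configuration alone: with nothing entering or leaving, redrawing a stereocentre at a saturated ring carbon from S to R gives an at least 2.2-fold lower number from compound 1 to compound 4 (0.34 log units; beyond the scatter) in this assay. The earlier compounds could not show that any change moves this number, as every one of them gave only a limit, and compound 4 now stands apart from them: the limit of > 10000 nM in this assay, at which 3 of the 4 values shown sit. The shift can be tied to this single stereocentre, which shows that the read-out responds to how this position is drawn, because no other feature separates the pair: the fact that compounds 1 and 4 differ only in the configuration as drawn

From the compounds shown here alone, compound 1 gives > 10000 nM, which is a limit, so the full size of the step remains unknown. Equally open, going by these compounds, is whether the other stereo elements count as much as this one, and what a longer chain or an amine at this place would do to the number in this assay.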